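The compounds below may be only part of what the source reports. "The series", "measured", "known", "first", "only" and "open" are said of these compounds alone.

Three compounds have so far been measured in a functional assay on SW-620 cells (Homo sapiens) for inhibition, read by MTT assay, with a stated time of 48 h; on this read-out higher numbers stand for weaker inhibition and lower numbers for stronger inhibition:

compound 1 `O=C(NC(=S)Nc1ccc(Cl)c(-c2nc3ccccc3[nH]2)c1)c1ccc(OCc2ccc(Cl)c(Cl)c2)cc1` gives 24900 nM
compound 2 `O=C(NC(=S)Nc1ccc(Cl)c(-c2nc3ccccc3[nH]2)c1)c1ccc(OCc2ccc(Cl)cc2Cl)cc1` gives 50200 nM
compound 3 `Cc1ccc(NC(=O)NC(=O)c2ccc(OCc3ccc(Cl)c(Cl)c3)cc2)cc1-c1nc2ccccc2[nH]1` gives 6100 nM

Compound 1 and compound 2 share one core and differ in a single place: 2,4-dichlorophenyl in place of 3,4-dichlorophenyl on a saturated chain carbon bound to an oxygen on an aromatic ring. The step this change made in this assay is a 2.0-fold higher number from compound 1 to compound 2 (0.30 log units; within the scatter). Compound 3 is built on another core; how that core differs from the core of compound 1 is not broken down here. Among the three measured compounds, compound 3 gives the lowest number, and its distance to both compound 1 and compound 2 lies beyond the scatter.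

Compound 4 `Cc1ccc(NC(=O)NC(=O)c2ccc(OCc3ccc(Cl)cc3Cl)cc2)cc1-c1nc2ccccc2[nH]1` has not yet been measured. It stands to compound 3 as compound 2 stands to compound 1: 2,4-dichlorophenyl in place of 3,4-dichlorophenyl on a saturated chain carbon bound to an oxygen on an aromatic ring. This is the same change, now made on the core of compound 3. Among the compounds with values here, for compound 4 the step in this assay is expected to be a 1.8-fold higher number from compound 3 to compound 4 (0.26 log units; within the scatter), because a 2.0-fold higher number from compound 1 to compound 2 (0.30 log units; within the scatter) is the only measured instance of this change, and that step sits within the scatter. Compound 4 is therefore estimated at 11000 nM in this assay. The expected range for compound 4 runs from 4000 nM to 30000 nM.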

Compound 4, half-maximal inhibitory concentration: 12200 nM
Compound 4: the middle estimate sits 1.1-fold (0.04 log units) below what was measured; low and high end bracket the measured number.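

In this assay, the exchange of 3,4-dichlorophenyl for 2,4-dichlorophenyl on the core of compound 3 gives a 2.0-fold higher number from compound 3 to compound 4 (0.30 log units; within the scatter). Set beside the earlier step, the change reads the same on both cores: the same change on two cores in this assay, a 2.0-fold higher number (0.30 log units; within the scatter) from compound 1 to compound 2 and a 2.0-fold higher number (0.30 log units; within the scatter) from compound 3 to compound 4, 1.0-fold (0.00 log units) apart, within the scatter of two such steps. Within the data shown here, both steps lie within the scatter, so the pair shows only that this exchange left no step beyond the scatter on either core; it does not show that the change has any real effect on the number, and two cores cannot tell whether the same would hold on a third core.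

The compounds shown carry only dichlorophenyl groups at this place, which leaves open how an unsubstituted phenyl, a methoxyphenyl or a phenyl bearing an amine or a carboxylic acid would read in this assay. Also open, on these data alone, is what a longer chain would do in place of the saturated chain carbon bound to an oxygen on an aromatic ring.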